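The compounds below may be only part of what the source reports. "The series", "measured", "known", "first", "only" and "open" are said of these compounds alone.

Of the compounds shown here, three built on one shared core have been measured in an assay for inhibition of Thromboxane-A synthase (Homo sapiens), using microsomes; a lower number here means a stronger inhibitor, a higher number a weaker inhibitor. Compound 1 `O=C(O)CC/C=C\CC1COC(c2ccccc2Cl)OC1c1cccnc1` gives 48 nM, compound 2 `N#Cc1ccc(C2OCC(C/C=C\CCC(=O)O)C(c3cccnc3)O2)cc1` gives 24 nM, and compound 3 `CC(C)(Oc1ccc(F)cc1)C1OCC(C/C=C\CCC(=O)O)C(c2cccnc2)O1` gives 51 nM. Compound 3 thus holds the highest of the three numbers, with compound 1 nearest to it and compound 2 furthest away. Within the data shown here, the only measured step, a 2.0-fold lower number from compound 1 to compound 2 (0.30 log units; within the scatter), alters the aryl group on a saturated ring carbon, whereas compound 4 `CC(C)(C1OCC(C/C=C\CCC(=O)O)C(c2cccnc2)O1)S(=O)(=O)c1ccccc1` differs from compound 3 elsewhere: phenylsulfonyl in place of 4-fluorophenoxy on a saturated chain carbon bound to two saturated chain carbons and a saturated ring carbon. Among the measured compounds shown here, no measured step bears directly on this change, and the one step known stayed within the scatter. The expectation in this assay is therefore no step beyond the scatter, giving for compound 4 an estimated 50 nM, ranging from 20 nM to 130 nM, a predicted move of a 1.0-fold lower number from compound 3 to compound 4 (0.01 log units; within the scatter).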

Compound 4, half-maximal inhibitory concentration: 40 nM
Estimate against measurement, compound 4: 1.3-fold (0.10 log units) above; the measured number falls inside the stated range.
By their numbers in this assay, from the lowest: compounds 2, 4, 1 and 3 (each within the scatter of the next, the first and the last beyond it).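

In this assay, phenylsulfonyl in place of 4-fluorophenoxy on a saturated chain carbon bound to two saturated chain carbons and a saturated ring carbon gives a 1.3-fold lower number from compound 3 to compound 4 (0.11 log units; within the scatter) and so stays within the scatter. This is the only step shown at this position, and it shows that these two groups, each carrying a six-membered aromatic ring of carbon only, read alike here. Nothing available gives a reason for this result. Still open, from the compounds shown here alone, is how this position responds to a group without such a ring, such as a primary amine or a plain methyl.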